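A few compounds are considered here, and "the series" means these few. Any claim that something is new, unique, unknown or untested is made for them only; others in the source may bear on it.

Three compounds share the same kind of build, an aromatic core carrying a long saturated chain, and have been tested in a functional assay on cells (Lymphocyte, Homo sapiens), read by trypan blue exclusion, with a stated time of 16 h, tested at 0.5 uM; on this read-out higher numbers stand for a stronger effect at the one concentration tested and lower numbers for a weaker effect. Compound 1, `CCCCCCCCCCCCCCCCc1c(C)c(N(C)C)nc(C)c1O`, gives 56% in this assay. Compound 2, `CCCCCCCCCCCCCCCCCCCc1c(C)c(N(C)C)nc(C)c1O`, differs from compound 1 only in the length of that chain, and in this assay compound 2 gives 8%. The change from compound 2 to compound 1 is hydrogen in place of propyl on a saturated chain carbon, ten or more bonds along the chain from an aromatic carbon, and the step it made was a number 48 percentage points higher from compound 2 to compound 1 (beyond the scatter). Compound 3, `CCCCCCCCCCCCCCCCCCCc1nc(N(C)C)c(C)c(C)c1O`, carries the same long chain as compound 2 on a core in which the same atoms are joined differently; the difference between the two cores is not broken down here. In this assay compound 3 gives 7%, a number that lies within the usual scatter of the number for compound 2.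

Compound 4, `CCCCCCCCCCCCCCCCc1nc(N(C)C)c(C)c(C)c1O`, has not yet been measured. It stands to compound 3 as compound 1 stands to compound 2: the change is hydrogen in place of propyl on a saturated chain carbon, ten or more bonds along the chain from an aromatic carbon, the same change at the same place. Among the measured compounds shown here, the step from compound 3 to compound 4 is expected to be a number 43 percentage points higher from compound 3 to compound 4 (beyond the scatter), and this expectation rests on the single earlier example, the step of a number 48 percentage points higher from compound 2 to compound 1 (beyond the scatter). For the measured compounds named here, only one such step is known, and the cores differ in a way not broken down. The range is kept wide. Compound 4 is therefore estimated at 50% in this assay, with the likely span running from 20% to 75%.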

Compound 4, a percentage reported as activity, at one concentration (the size of the read-out at that concentration, not a potency): 78%
Beside the measured number, compound 4's estimate is 28 percentage points below it; measured number outside the range, above it.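

In this assay, putting hydrogen in place of propyl at this place on the chain raises the number on the second core as well, giving a number 71 percentage points higher from compound 3 to compound 4 (beyond the scatter), so the direction of the change carries over between these two cores. The size of the step does not carry over unchanged, and a step measured on one core would not have given a close figure for the other: the same change on two cores in this assay, a number 48 percentage points higher (beyond the scatter) from compound 2 to compound 1 and a number 71 percentage points higher (beyond the scatter) from compound 3 to compound 4, 23 percentage points apart, beyond the scatter of two such steps This does not show why the two steps differ in size, and two cores are too few to say that the same direction would hold on a third; each number also comes from one concentration, so neither step is a change in potency.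

The compounds shown leave open how the number moves along the series of chain lengths, whether for a chain of intermediate length or for one shorter than any here, and so whether the effect rises steadily or peaks somewhere. They also leave open what would happen if the chain carried an amine or a carboxylic acid, or if the dimethylamino group on the core gave way to a simple amine.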